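The compounds below may be only part of what the source reports. "The series", "measured", "known", "first", "only" and "open" are said of these compounds alone.

Measured so far in an ADME assay on HEK-293T cells (Homo sapiens) for antiproliferative activity, read by MTT assay, with a stated time of 48 h, in the presence of a further agent that is not named here; a higher number here means that more compound is tolerated, a lower number that less compound is tolerated:
compound 1 `O=C(NOCc1ccccc1)c1cn(-c2ccccc2)nc1-c1ccccc1` gives 122000 nM
compound 2 `COc1ccc(-c2nn(-c3ccccc3)cc2C(=O)NOCc2ccccc2)cc1` gives 201000 nM

Compound 2 holds the higher of the two numbers, though a 1.6-fold higher number from compound 1 to compound 2 (0.22 log units; within the scatter) is within the scatter, so the two stand level. Compound 3 `O=C(NOCc1ccccc1)c1cn(-c2ccccc2)nc1-c1ccc(Cl)cc1` differs from compound 2 by chloro in place of methoxy on an aromatic carbon. Among the compounds with values here, no measured step exchanges two substituents at this position; the single step on this aromatic carbon, from hydrogen to methoxy, stayed within the scatter. With nothing to point beyond that, compound 3 is expected near compound 2, with a 1.3-fold lower number from compound 2 to compound 3 (0.13 log units; within the scatter) inside the scatter. Compound 3 is estimated at 150000 nM, within 60000 nM to 400000 nM.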

Compound 3, half-maximal cytotoxic concentration: 51900 nM
Estimate against measurement, compound 3: 2.9-fold (0.46 log units) above, and the stated range ends above it.
By their numbers in this assay, from the lowest: compound 3; then compounds 1 and 2 (each within the scatter of the next).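

Position note: the aromatic carbon para to a large group does respond in this assay, since 4-methoxyphenyl to 4-chlorophenyl gives a 3.9-fold lower number from compound 2 to compound 3 (0.59 log units; beyond the scatter) and the earlier hydrogen to methoxy step had stayed within the scatter. Chloro also separates from hydrogen, with a 2.4-fold lower number from compound 1 to compound 3 (0.37 log units; beyond the scatter) as the step, so less compound is tolerated with chloro here than with either other group. Nothing available bears on the reason for this shift.

Open: whether other groups at this carbon, such as an amine, a carboxylic acid or a longer chain, follow chloro or stay level with hydrogen and methoxy. Going by these compounds, whether chloro acts the same way elsewhere on the core also remains open.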